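The compounds below may be only part of what the source reports. "The series", "measured", "known", "first", "only" and "open" are said of these compounds alone.

Compound 1 `Cn1c2c(c3ccccc3c1=O)CCOc1ccccc1-2` and compound 2 `Cc1ccc2c(=O)n(C)c3c(c2c1)CCOc1ccccc1-3` share one core, while compound 3 `COCOc1ccccc1-c1cc2ccccc2c(=O)n1C` and compound 4 `COCOc1ccccc1-c1cc2cc(C)ccc2c(=O)n1C` share another; the difference between the two cores is not broken down here. In a functional assay on A549 cells (Homo sapiens) for cytotoxicity, read by sulforhodamine B assay (a lower number here means a stronger inhibitor, a higher number a weaker inhibitor), compound 1 gives 66800 nM. The change methyl in place of hydrogen on an aromatic carbon gives a 1.1-fold lower number from compound 1 to compound 2 (0.04 log units; within the scatter), and compound 2 gives 61300 nM. For compound 3 this assay reports only a limit, > 100000 nM. The change methyl in place of hydrogen on an aromatic carbon is the same kind of change, though here the six-membered aromatic ring is part of a fused or bridged system of two rings rather than four. Since compound 3 sits at the limit of > 100000 nM in this assay, at which 1 of the 3 values shown sits, compound 4 is expected to remain near that limit, an estimated step that the limit leaves unreadable from compound 3 to compound 4. Compound 4 is therefore estimated at 120000 nM, between 60000 nM and 250000 nM.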

Compound 4, half-maximal inhibitory concentration: 99800 nM
The estimate for compound 4 lay 1.2-fold (0.08 log units) above the measured number; measured number inside the range.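

In this assay compound 3 gives > 100000 nM, which is a limit of the assay and not a number, so the size of the step to compound 4 cannot be read. Methyl in place of hydrogen on an aromatic carbon gives a number no higher from compound 3 to compound 4 (the limit leaves the size open). Setting methyl in place of hydrogen on an aromatic carbon on the two cores therefore gives only a partial comparison: the same change on two cores in this assay, a 1.1-fold lower number (0.04 log units; within the scatter) from compound 1 to compound 2 and a number no higher (the limit leaves the size open) from compound 3 to compound 4; the limit leaves it open whether they differ. The series thus shows that this change stays within the scatter on the core of compound 1, but it does not show whether the change carries over to the core of compound 3 with the same size.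

The compounds shown have only hydrogen or methyl at this place on the aromatic ring. From the compounds shown here alone, how a longer chain, a chlorine atom, an amine or a carboxylic acid there would read in this assay remains open.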